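The source may hold more compounds than are shown below. What is called first, only, known or untested is meant among the compounds shown, and "the series" means these compounds.

Working notes on the series. Among the compounds with values here, in a functional assay on PC-3 cells (Homo sapiens) for cytotoxicity, read by sulforhodamine B assay, with a stated time of 48 h (a higher number here means a weaker inhibitor, a lower number a stronger inhibitor), compound 2 (`C[C@H]1CC[C@@H]2[C@@H](OC(=O)[C@]23CC(c2ccc(N(C)C)cc2)=NO3)[C@]2(C)C(=O)C=C[C@@]12O`) gives 6300 nM, the lower of the two numbers so far, and compound 1 (`C[C@H]1CC[C@@H]2[C@@H](OC(=O)[C@]23CC(c2ccccc2Br)=NO3)[C@]2(C)C(=O)C=C[C@@]12O`) gives 51000 nM. The unmeasured compound 3 (`COc1cc(C2=NO[C@]3(C2)C(=O)O[C@@H]2[C@H]3CC[C@H](C)[C@]3(O)C=CC(=O)[C@@]23C)ccc1O`) carries 4-hydroxy-3-methoxyphenyl in place of 4-(dimethylamino)phenyl on a carbon with a double bond to nitrogen of a five-membered non-aromatic ring with 1 nitrogen and 1 oxygen: 4-hydroxy-3-methoxyphenyl in place of 4-(dimethylamino)phenyl on a carbon with a double bond to nitrogen.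

Within the data shown here, only one measured step bears on this change: an 8.1-fold lower number from compound 1 to compound 2 (0.91 log units; beyond the scatter). It is a modest step, and it shows that exchanging the group at this place can move the number beyond the scatter. Among the measured compounds shown here, it does not involve the entering group, and no measured compound carries 4-hydroxy-3-methoxyphenyl, so the reading is indirect. Compound 2 holds the lower number, so a modest rise toward the value of compound 1 is the working expectation, smaller than the measured step. The estimated step in this assay is a 2.4-fold higher number from compound 2 to compound 3 (0.38 log units; beyond the scatter). For compound 3 the expected value is 15000 nM, with an estimated range of 5000 nM to 45000 nM.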

Compound 3, half-maximal inhibitory concentration: 16000 nM
Beside the measured number, compound 3's estimate is 1.1-fold (0.03 log units) below it; low and high end bracket the measured number.
By their numbers in this assay, from the lowest: compound 2; then compound 3; then compound 1.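

In this assay, a third group at this place gives a 2.5-fold higher number from compound 2 to compound 3 (0.40 log units; beyond the scatter) and a 3.2-fold lower number from compound 1 to compound 3 (0.50 log units; beyond the scatter), so the three groups tested here give three separable numbers, each step beyond the scatter. 4-Hydroxy-3-methoxyphenyl therefore takes the middle of the three, and compound 2 keeps the lowest number. 4-(Dimethylamino)phenyl and 4-hydroxy-3-methoxyphenyl each have 9 heavy atoms and one six-membered aromatic ring of carbon only. These two compounds show that the number at this place is not fixed by heavy-atom count or by that ring alone.

The compounds shown do not separate the contributions of the hydroxy and methoxy parts of the entering group, and a 4-hydroxyphenyl or 3-methoxyphenyl group would be needed to read each part alone. From the compounds shown here alone, it also remains open how a group without an aromatic ring, such as a simple amine, a carboxylic acid or a longer alkyl chain, would read on this carbon with a double bond to nitrogen.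

No measurement available here gives a reason for these differences.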